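Adding one methyl to the ethyl chain of compound 2

The source may hold more compounds than are shown below. What is called first, only, known or untested is meant among the compounds shown, and "the series" means these compounds.

Compound 1 `Cc1nc(O)c(C#N)c(NCc2ccncc2)n1` gives 250000 nM
Compound 2 `CCc1nc(O)c(C#N)c(NCc2cccnc2)n1` gives 86000 nM

In a functional assay with Felis catus as the target (a lower number here means that less compound is needed, a higher number that more compound is needed for the effect), compound 2 stands lowest of the two at 86000 nM and its gap to compound 1 lies beyond the scatter. Compound 3 `CC(C)c1nc(O)c(C#N)c(NCc2cccnc2)n1` is not yet measured. It differs from compound 2 by methyl in place of hydrogen on a saturated chain carbon bound to an aromatic carbon and a saturated chain carbon as ethyl becomes isopropyl, methyl in place of hydrogen on a saturated chain carbon bound to an aromatic carbon and a saturated chain carbon. For the measured compounds named here, no single-change step has been measured, so in this assay only a small shift toward a lower number, within the scatter, is expected. The expected move is a 1.4-fold lower number from compound 2 to compound 3 (0.16 log units; within the scatter) in this estimate. Compound 3 is estimated at 60000 nM with an expected range of 20000 nM to 180000 nM around it.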

Compound 3, half-maximal effective concentration: 10000 nM
Beside the measured number, compound 3's estimate is 6.0-fold (0.78 log units) above it; measured number outside the range, below it.
By their numbers in this assay, from the lowest: compound 3; then compound 2; then compound 1.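

In this assay, for the compounds shown here, the change from ethyl to isopropyl gives an 8.6-fold lower number from compound 2 to compound 3 (0.93 log units; beyond the scatter), the first single-change step here, and it lies beyond the scatter. One added methyl on this saturated chain carbon bound to an aromatic carbon is thus enough to move the number clearly, which compound 1 and compound 2, differing in more than one place, could not show. No evidence at hand accounts for this shift.

Open, going by these compounds, is whether branching itself matters or whether a straight propyl chain would match isopropyl. Also open, on these data alone, is whether a tert-butyl group or a cyclopropyl ring would move the number further.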